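The source may report more compounds than this note shows. Statements on the series, on what has been measured and on what is new or still open speak of the compounds shown alone.

In a functional assay on FL5.12 cells (Mus musculus) for cytotoxicity, read by flow cytometry, with a stated time of 48 h (a higher number here means a weaker inhibitor, a lower number a stronger inhibitor), compound 1 `CCCC/C=C/c1ccc(CO[C@H]2CN[C@H](CO)C2)cc1` gives 5700 nM and compound 2 `CCCCCCCCCCCCO[C@@H]1CN[C@@H](CO)C1` gives 1200 nM as the lower number of the two. That gap lies beyond the scatter, so compound 2 is the stronger inhibitor of this pair. Compound 3 `CCCCCCCCCCCCO[C@H]1CN[C@H](CO)C1` has not been measured yet. The change from compound 2 is the two compounds have the same atoms and bonds and differ only in configuration as drawn: 2 of 2 stereo elements differ (all stereocentres are inverted: mirror images); a stereocentre at a saturated ring carbon is drawn S in compound 2 and R in compound 3; a stereocentre at a saturated ring carbon is drawn R in compound 2 and S in compound 3 and nothing else: the two compounds have the same atoms and bonds, and all stereocentres are inverted, so they are mirror images. Going by the values given here, no measured pair here shows what such an inversion does. In this assay the expected step is therefore small, none beyond the scatter, with a slight lean towards a higher number than compound 2 shows at 1200 nM so far. An estimated 1.3-fold higher number from compound 2 to compound 3 (0.10 log units; within the scatter) is expected. Compound 3 is estimated at 1500 nM with an expected range from 700 nM to 3200 nM in this measurement.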

Compound 3, half-maximal inhibitory concentration: 2500 nM
Estimate against measurement, compound 3: 1.7-fold (0.22 log units) below, and the stated range covers the measured number.
By their numbers in this assay, from the lowest: compound 2; then compound 3; then compound 1.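

In this assay, inverting both stereocentres at the saturated ring carbons gives a 2.1-fold higher number from compound 2 to compound 3 (0.32 log units; beyond the scatter), the first measured sign that configuration matters in this series. The step is modest, so the mirror image stays active in the same general range, and handedness shifts the number without abolishing the effect. The step can be traced to one source only: the fact that compounds 2 and 3 differ only in the configuration as drawn.

From the compounds shown here alone, both stereocentres change together here, so it remains open whether one of them carries the step or both contribute. Going by these compounds, it also remains open whether the same preference for the configuration of compound 2 would hold with a shorter chain on the ether oxygen, or with a carboxylic acid in place of the alcohol.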